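The source may report more compounds than this note shows. Statements on the series, on what has been measured and on what is new or still open speak of the compounds shown alone.

In a functional assay on K562 cells (Homo sapiens) for antiproliferative activity, read by MTT assay, with a stated time of 72 h (on this read-out lower numbers stand for stronger inhibition and higher numbers for weaker inhibition), three compounds have been measured so far. Compound 1 (`CN1CCN(c2ccc(C(=O)/C=C/c3cccc(/C=C/C(=O)NO)c3)cc2)CC1`) gives 1170 nM, compound 2 (`O=C(/C=C/c1cccc(/C=C/C(=O)c2ccccc2)c1)NO`) gives 3210 nM, and compound 3 (`CN1CCN(c2ccccc2C(=O)/C=C/c2ccc(/C=C/C(=O)NO)cc2)CC1`) gives 1600 nM. Compound 3 lies within the usual scatter of both others, so it cannot be ranked against either of them, although compound 1 and compound 2 are themselves separated by more than that scatter.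

The next structure is compound 4 (`O=C(/C=C/c1ccc(/C=C/C(=O)c2ccccc2)cc1)NO`). It is compound 3 with hydrogen in place of 4-methylpiperazin-1-yl on an aromatic carbon, ortho to a large group: hydrogen in place of 4-methylpiperazin-1-yl on an aromatic carbon.

Among the compounds with values here, only one measured step makes the same exchange: a 2.7-fold higher number from compound 1 to compound 2 (0.44 log units; beyond the scatter). This is a modest step, beyond the scatter, towards weaker inhibition. It is a single example, and the core of compound 1 differs from the core of compound 3, so it serves as a guide and not as a rule. On that evidence, a step of similar size in the same direction, towards a higher number, is expected in this assay. The expected step is a 2.5-fold higher number from compound 3 to compound 4 (0.40 log units; beyond the scatter). For compound 4 the estimated value is 4000 nM, with an expected range from 1800 nM to 9000 nM.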

Compound 4, half-maximal inhibitory concentration in the K562 assay: 2280 nM
For compound 4 the middle estimate is 1.8-fold (0.24 log units) above the measured one, within the range that was stated.
By their numbers in the K562 assay, from the lowest: compounds 1, 3, 4 and 2 (each within the scatter of the next, the first and the last beyond it).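

In the K562 assay, exchanging 4-methylpiperazin-1-yl for hydrogen on this aromatic carbon, ortho to a large group, gives a 1.4-fold higher number from compound 3 to compound 4 (0.15 log units; within the scatter), so on this core the exchange produces no readable change in the read-out. Set beside the earlier step on the core of compound 1, this result does not show that the two cores respond differently: the same change on two cores in the K562 assay, a 2.7-fold higher number (0.44 log units; beyond the scatter) from compound 1 to compound 2 and a 1.4-fold higher number (0.15 log units; within the scatter) from compound 3 to compound 4, 1.9-fold (0.28 log units) apart, within the scatter of two such steps. The new information comes from a physicochemical assay for solubility, at pH 7.4 (on this read-out higher numbers stand for higher solubility and lower numbers for lower solubility), where compound 3 gives 210000 nM and compound 4 gives 3000 nM and the same exchange is far from silent, with a much lower number for the compound without the 4-methylpiperazin-1-yl group, a large loss of solubility with no readable change in the cell result: the measured solubility of compound 3, 210000 nM, and of compound 4, 3000 nM, a 70-fold lower number (1.85 log units; beyond the scatter).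

On these data alone, it remains open whether a smaller amine such as dimethylamino, or a morpholine ring, on this aromatic carbon would keep a number close to that of compound 3 in the physicochemical assay, which would indicate how much of the 4-methylpiperazin-1-yl group is needed. Also open, as far as these compounds go, is how large the step in the physicochemical assay would be for the same exchange on the core of compound 1.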